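The source may hold more compounds than are shown below. What is called first, only, known or untested is meant among the compounds shown, and "the series" means these compounds.

Four compounds from one study are considered here, all measured or to be measured in a functional assay on cells (Cancer cell lines, Homo sapiens) for cytotoxicity, read by sulforhodamine B assay, with a stated time of 48 h; a higher number here means a weaker inhibitor of growth, a lower number a stronger inhibitor of growth. Compound 1 `COc1ccc(C2CC(c3ccccc3)=NN2C2=NC(=O)/C(=C3\C(=O)Nc4ccccc43)S2)cc1` and compound 2 `COc1ccc(C2CC(c3ccccc3)=NN2C2=NC(=O)/C(=C3\C(=O)Nc4ccc(Br)cc43)S2)cc1` share one core. In this assay compound 1 gives 4580 nM, while compound 2 gives 480 nM. The change between them is bromo in place of hydrogen on an aromatic carbon, and it made a 9.5-fold lower number from compound 1 to compound 2 (0.98 log units; beyond the scatter).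

Compound 3 `COc1ccc(C2=NN(C3=NC(=O)/C(=C4\C(=O)Nc5ccccc54)S3)C(c3ccc(Cl)cc3)C2)cc1` is built on a different core; the difference between the two cores is not broken down here. In this assay, going by the values given here, compound 3 gives 100000 nM, the highest of the three numbers so far, and the gap to compound 1 and to compound 2 is in each case beyond the scatter.

Compound 4 `COc1ccc(C2=NN(C3=NC(=O)/C(=C4\C(=O)Nc5ccc(Br)cc54)S3)C(c3ccc(Cl)cc3)C2)cc1` has not yet been measured. It differs from compound 3 by bromo in place of hydrogen on an aromatic carbon, which is the same change that turns compound 1 into compound 2, at the same place on the ring. Among the compounds with values here, only one measured example of this change exists, and the core of compound 3 is not the core of compound 1, so the expectation rests on that single step alone. Within the data shown here, compound 4 is expected to move by a 6.7-fold lower number from compound 3 to compound 4 (0.82 log units; beyond the scatter) in this assay, a step estimated to be of roughly the size seen from compound 1 to compound 2, because a 9.5-fold lower number from compound 1 to compound 2 (0.98 log units; beyond the scatter) is the only guide available. The estimate for compound 4 is therefore 15000 nM, with a range from 3000 nM to 100000 nM.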

Compound 4, concentration for total growth inhibition: 400 nM
Compound 4: middle estimate off by 38-fold (1.57 log units), on the high side; measured number outside the range, below it.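

In this assay, bromo in place of hydrogen on an aromatic carbon lowered the number again, with a 250-fold lower number from compound 3 to compound 4 (2.40 log units; beyond the scatter), so the direction of the step held on both cores shown. The size of the step did not carry over, and the two steps differ by more than the scatter of such steps: the same change on two cores in this assay, a 9.5-fold lower number (0.98 log units; beyond the scatter) from compound 1 to compound 2 and a 250-fold lower number (2.40 log units; beyond the scatter) from compound 3 to compound 4, 26-fold (1.42 log units) apart, beyond the scatter of two such steps. In this series, then, the direction of the change was shared by the core of compound 1 and the core of compound 3, but the size of the step on one core was a poor guide to its size on the other; two pairs do not show why the sizes differ, nor whether the direction would hold on a further core.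

The compounds shown carry only hydrogen or bromo at this place on the ring, which leaves open whether a smaller halogen such as fluoro, a nitrile, an amine or a carboxylic acid there would lower the number as well, and by how much on each core. They also leave open which feature of the difference between the two cores goes with the larger step.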